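A few compounds are considered here, and "the series" means these few. Any claim that something is new, unique, unknown or untested is made for them only; others in the source may bear on it.

Numbers in a functional assay on NCI-H1299 cells (Homo sapiens) for antiproliferative activity, read by XTT assay, with a stated time of 72 h (a lower number here means a stronger inhibitor, a higher number a weaker inhibitor), for the measured members of the series:

compound 1 `COc1ccc(C(=O)/C=C/c2nc3ccccc3cc2-c2ccc(OC)cc2)cc1`: 6420 nM
compound 2 `COc1ccc(-c2cc3ccccc3nc2/C=C/C(=O)c2ccco2)cc1`: 730 nM
compound 3 `COc1ccc(-c2cc3ccccc3nc2/C=C/C(=O)c2ccsc2)cc1`: 1220 nM

Compound 3 holds the second highest of the three numbers. Its nearest neighbour is compound 2, with a 1.7-fold higher number from compound 2 to compound 3 (0.22 log units; within the scatter); the two are not separable. The furthest is compound 1, with a 5.3-fold lower number from compound 1 to compound 3 (0.72 log units; beyond the scatter).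

The next member is compound 4 `COc1ccc(-c2cc3ccccc3nc2/C=C/C(=O)c2ccc[nH]2)cc1`. Against compound 3 the change is 1H-pyrrol-2-yl in place of thiophen-3-yl on a carbonyl carbon.

Going by the values given here, two measured steps bear on this position. Both an 8.8-fold lower number from compound 1 to compound 2 (0.94 log units; beyond the scatter) and a 5.3-fold lower number from compound 1 to compound 3 (0.72 log units; beyond the scatter) replace the 4-methoxyphenyl on the carbonyl carbon by a five-membered heteroaryl with one hetero atom, and both move the number down by a modest amount. Between the two heteroaryls themselves, a 1.7-fold higher number from compound 2 to compound 3 (0.22 log units; within the scatter) stays within the scatter. Among the compounds with values here, no measured step swaps in a ring carrying a hydrogen-bond donor, so the effect of the pyrrole nitrogen-hydrogen is not covered. The present reading is therefore that compound 4 should sit in the same band as compounds 2 and 3, with no step beyond the scatter expected in this assay in either direction.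

Compound 4 is estimated at 1000 nM, in the range 400 nM to 2600 nM, meaning an expected step of a 1.2-fold lower number from compound 3 to compound 4 (0.09 log units; within the scatter).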

Compound 4, half-maximal inhibitory concentration: > 10000 nM
Compound 4: no number, only a limit; the forecaster's own chance of this, stated with the estimate: 3%; middle value at least 10-fold (1.00 log units) from the limit.
By their numbers in this assay, from the lowest: compounds 2 and 3 (each within the scatter of the next); then compound 1. At a limit, above all of these: compound 4.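

In this assay compound 4 has no number, only a limit: the limit of > 10000 nM in this assay, at which 1 of the 4 values shown sits.

Read against that limit, 1H-pyrrol-2-yl on the carbonyl carbon parts from both earlier five-membered rings, with an at least 8.1-fold higher number from compound 3 to compound 4 (0.91 log units; beyond the scatter) and an at least 13-fold higher number from compound 2 to compound 4 (1.13 log units; beyond the scatter). The position therefore does not treat every five-membered aromatic ring with one hetero atom alike, although furan-2-yl and thiophen-3-yl could not be separated from each other. Against the 4-methoxyphenyl group the reading is less firm, with an at least 1.5-fold higher number from compound 1 to compound 4 (0.19 log units; that floor lies within the scatter), so the heteroaryl gain seen in compound 2 and compound 3 does not extend to compound 4, while compound 1 and compound 4 are not shown to differ beyond the scatter.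

What drives the loss stays open: 1H-pyrrol-2-yl brings a hydrogen-bond donor that thiophen-3-yl lacks, but the ring nitrogen and the donor hydrogen are not separated by any compound shown. A 1-methyl-1H-pyrrol-2-yl group, or a 1H-pyrrol-3-yl group, on the same carbonyl carbon would tell the nitrogen-hydrogen apart from the ring itself and from its point of attachment.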